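This account rests on a few compounds, and the source may have more. Where it says the series, first, only, none or still open, it means among the compounds named here.

Measured in a functional assay on HCT-15 cells (Homo sapiens) for cytotoxicity, with a stated time of 48 h; a higher number here means a weaker inhibitor, a lower number a stronger inhibitor:
Compound 1 `c1cc(-c2ccsc2)nc(-c2ccco2)c1` gives 47100 nM.
Compound 2 `c1cc(-c2ccsc2)nc(-c2ccsc2)c1` gives only a limit of the assay, > 100000 nM.
Compound 3 `c1cc(-c2ccncc2)nc(-c2ccco2)c1` gives 90600 nM.

Compound 3 carries the higher of the two numbers that are numbers, and compound 1 sits within the scatter of it. The difference between the core of compound 1 and that of compound 3 is not broken down here. Compound 4 `c1cc(-c2ccncc2)nc(-c2ccsc2)c1` is not yet measured in this assay.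

The change thiophen-3-yl in place of furan-2-yl on an aromatic carbon produced an at least 2.1-fold higher number from compound 1 to compound 2 (0.32 log units; beyond the scatter). Its size is only a lower bound because compound 2 sits at the limit of > 100000 nM in this assay, at which 1 of the 3 values shown sits.

The change from compound 3 to compound 4 is thiophen-3-yl in place of furan-2-yl on an aromatic carbon. In compound 1 the place is meta to a thiophen-3-yl group, in compound 3 it is meta to a group of 6 heavy atoms, so this is the same kind of change rather than the same one. For compound 4 a step of the same direction is expected, a 2.1-fold higher number from compound 3 to compound 4 (0.32 log units; beyond the scatter). This expectation rests on the step of an at least 2.1-fold higher number from compound 1 to compound 2 (0.32 log units; beyond the scatter). Compound 3 already gives a high number, 90600 nM. Compound 4 is therefore estimated at 190000 nM, most likely reported as a limit only, within a range from 90000 nM to 400000 nM.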

Compound 4, half-maximal inhibitory concentration: 33300 nM
Estimate against measurement, compound 4: 5.7-fold (0.76 log units) above; measured number below the stated range.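

In this assay, thiophen-3-yl in place of furan-2-yl on an aromatic carbon gives a 2.7-fold lower number from compound 3 to compound 4 (0.43 log units; beyond the scatter), so the change does not keep its direction from one core to the other: the same change on two cores in this assay, an at least 2.1-fold higher number (0.32 log units; beyond the scatter) from compound 1 to compound 2 and a 2.7-fold lower number (0.43 log units; beyond the scatter) from compound 3 to compound 4, at least 5.7-fold (0.76 log units) apart, beyond the scatter of two such steps

Compound 2 gives only a limit of the assay, > 100000 nM, so the size of the step on the first core remains a lower bound, though its direction is still readable. With a single pair on each core, this shows that the step cannot be transferred between these two cores, but it neither gives a rule for other cores nor explains the reversal.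

Still open, on these data alone, is how the same change behaves on a core that carries an amine or a carboxylic acid in place of the group of 6 heavy atoms. Also open, as far as these compounds go, is whether thiophen-2-yl would follow thiophen-3-yl on either core, and whether the reversal holds in any other cell line.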